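Notes on the triazole-linked variant of compound 1

A few compounds are considered here, and "the series" means these few. Any claim that something is new, unique, unknown or untested is made for them only; others in the source may bear on it.

Compound 1 `O=C1c2c[n+]([O-])c3ccccc3c2C(=O)c2c1c1ccccc1n2Cc1cn([C@H]2C[C@H](O)[C@@H](CO)O2)nn1` is the starting point. In a functional assay on SH-SY5Y cells (Homo sapiens) for cytotoxicity, read by MTT assay, with a stated time of 72 h (a lower number here means a stronger inhibitor, a higher number a weaker inhibitor), compound 1 gives 620 nM, which stands second highest among the three numbers recorded so far. The two neighbours carry different chains on the same indole nitrogen of the shared core: compound 3 `O=C1c2c[n+]([O-])c3ccccc3c2C(=O)c2c1c1ccccc1n2CCN1CCCC1` gives 520 nM in this assay, and compound 2 `O=C1c2c[n+]([O-])c3ccccc3c2C(=O)c2c1c1ccccc1n2CCCCN1CCNCC1` gives 1240 nM. Compound 1 sits within the usual scatter of both.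

Among the measured compounds shown here, the only step recorded is a 2.4-fold lower number from compound 2 to compound 3 (0.38 log units; beyond the scatter), and it concerns the chain on the indole nitrogen, not the part of the molecule that changes here. Compound 4 `CC1(C)OC[C@@H](Cn2cc(Cn3c4c(c5ccccc53)C(=O)c3c[n+]([O-])c5ccccc5c3C4=O)nn2)O1` differs from compound 1 at the triazole: (2,2-dimethyl-1,3-dioxolan-4-yl)methyl in place of 4-hydroxy-5-(hydroxymethyl)oxolan-2-yl on an aromatic nitrogen. For the measured compounds named here, no measured pair shows the effect of swapping one sugar-like group for another on that ring nitrogen, so the step from compound 1 to compound 4 rests on the observation that all three chain variants so far fall within a narrow band.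

The expectation is therefore a small step, a 1.1-fold higher number from compound 1 to compound 4 (0.05 log units; within the scatter), not beyond the scatter and with no direction claimed. For compound 4 the estimate in this assay is 700 nM, with a range from 300 nM to 1600 nM.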

Compound 4, half-maximal inhibitory concentration: > 1000 nM
Compound 4 ended at the assay's limit; the forecaster's own chance of this, stated with the estimate: 5%; middle value at least 1.4-fold (0.15 log units) away from the limit.
By their numbers in this assay, from the lowest: compounds 3, 1 and 2 (each within the scatter of the next, the first and the last beyond it).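

In this assay compound 4 gives > 1000 nM, which is a limit of the assay and not a number: the limit of > 1000 nM in this assay, at which 1 of the 4 values shown sits.

Among the compounds shown here, this is the first reading at the aromatic nitrogen of the five-membered aromatic ring with 3 nitrogen, where (2,2-dimethyl-1,3-dioxolan-4-yl)methyl in place of 4-hydroxy-5-(hydroxymethyl)oxolan-2-yl gives an at least 1.6-fold higher number from compound 1 to compound 4 (0.20 log units; that floor lies within the scatter). The floor of that step lies within the scatter, so the result establishes no difference of a stated size at this position, and it leaves compound 4 without a place in the order of the other three compounds.

For the compounds shown here, the swap changes several counted features at once, from 2 hydrogen-bond donors to 0 and from 3 defined stereocentres to 1, and the single pair cannot tell which of them, if any, goes with the step. The compounds shown also leave open how an amine, a carboxylic acid or a plain alkyl chain on that same aromatic nitrogen would read in this assay, and whether an open-chain diol in place of the dioxolane ring would read closer to compound 1.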